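A few compounds are considered here, and "the series" means these few. Any claim that something is new, unique, unknown or untested is made for them only; others in the source may bear on it.

Compound 1 `COc1cc(OC)c(OC)cc1/C=C/COC(=O)/C=C/c1ccccc1C(F)(F)F` gives > 710 umol/kg as a limit
Compound 2 `COc1cc(OC)c(OC)cc1/C=C/COC(=O)/C=C/c1cccc(Br)c1` gives 497 umol/kg as a number
Compound 3 `COc1cc(OC)c(OC)cc1/C=C/COC(=O)/C=C/c1ccc(F)cc1` gives > 805 umol/kg as a limit

All three values come from a functional assay on the whole organism (strain Kunming) with Mus musculus as the target, with a stated time of 0.5 h (on this read-out higher numbers stand for an effect only at larger amounts of compound and lower numbers for an effect already at smaller amounts), and the compounds differ only in the substituted phenyl group. Compound 3 stands at the limit of > 805 umol/kg in this assay, at which 1 of the 3 values shown sits, and so has a limit, not a number. Compound 1 stands at the limit of > 710 umol/kg in this assay, at which 1 of the 3 values shown sits, and has a limit too.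

The change from compound 3 to compound 4 `COc1ccc(/C=C/C(=O)OC/C=C/c2cc(OC)c(OC)cc2OC)cc1` is 4-fluorophenyl to 4-methoxyphenyl, that is, methoxy in place of fluoro on an aromatic carbon and compound 4 has not yet been measured. Going by the values given here, no measured step brings in methoxy, so the only guidance comes from other changes of this phenyl group. One is an at least 1.6-fold higher number from compound 2 to compound 3 (0.20 log units; that floor lies within the scatter) and another is an at least 1.4-fold lower number from compound 1 to compound 2 (0.15 log units; that floor lies within the scatter) while the third, a step that the two limits leave unreadable from compound 1 to compound 3 gives no usable size. None of these steps is shown beyond the scatter, so no step beyond the scatter, in either direction, is expected in this assay for this change.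

The expected step is an at least 1.2-fold lower number from compound 3 to compound 4 (0.09 log units; that floor lies within the scatter) and it remains an estimate that a limit alone could replace. For compound 4 the estimated value is 650 umol/kg with an expected range of 280 umol/kg to 1100 umol/kg.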

Compound 4, dose for half-maximal effect: > 780 umol/kg
Compound 4 was reported as a limit (the forecaster's own chance of this, stated with the estimate: 50%); middle value at least 1.2-fold (0.07 log units) from the limit.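

In this assay compound 4 gives a limit and not a number: the limit of > 780 umol/kg in this assay, at which 1 of the 4 values shown sits. Going by these compounds alone, the first group with an oxygen at this aromatic carbon, para to a large group, therefore ends like fluoro in a limit, and compound 2 remains the only one of the four compounds with a number. an at least 1.5-fold higher number from compound 2 to compound 4 (0.19 log units; that floor lies within the scatter) is the only readable step, and its floor does not separate the two compounds, while the steps from compound 3 and from compound 1 to compound 4 cannot be read, since both ends of each are limits.

Going by these compounds, how far compound 1, compound 3 and compound 4 really lie from their limits stays open, so neither the size nor the direction of the exchange of fluoro for methoxy is known in this read-out. Also open, on these data alone, is whether a 4-bromophenyl group would give a number as the 3-bromophenyl group of compound 2 does, and whether an amine or a carboxylic acid on this same aromatic carbon would give a number at all.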